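Benzyl ether variation in a thiourea series: compound 3

The source may report more compounds than this note shows. Statements on the series, on what has been measured and on what is new or still open speak of the compounds shown alone.

Measured so far:
compound 1 `Cc1ccc(NC(=S)NC(=O)c2ccc(OCc3ccccc3F)cc2)cc1-c1nc2ccccc2[nH]1` — 6440 nM
compound 2 `Cc1ccc(NC(=S)NC(=O)c2ccc(OCc3ccc(Cl)cc3Cl)cc2)cc1-c1nc2ccccc2[nH]1` — 57200 nM

In a functional assay on SW-620 cells (Homo sapiens) for inhibition, read by MTT assay, with a stated time of 48 h (a higher number here means a weaker inhibitor, a lower number a stronger inhibitor), compound 2 gives 57200 nM, the highest of the two numbers recorded; its nearest neighbour is compound 1, where the step of an 8.9-fold higher number from compound 1 to compound 2 (0.95 log units; beyond the scatter) lies beyond the scatter. Compound 3 `Cc1ccc(NC(=S)NC(=O)c2ccc(OCc3ccc(F)cc3)cc2)cc1-c1nc2ccccc2[nH]1` has not been measured. It differs from compound 2 by 4-fluorophenyl in place of 2,4-dichlorophenyl on a saturated chain carbon bound to an oxygen on an aromatic ring. Going by the values given here, the only measured step that bears on this change is an 8.9-fold higher number from compound 1 to compound 2 (0.95 log units; beyond the scatter), which shows that exchanging 2-fluorophenyl for 2,4-dichlorophenyl at the same place raises the number. Compound 3 returns to a single fluorine on that ring, though at a different position from compound 1, so the bulk of that step is expected to reverse, without full confidence that a 4-fluorophenyl behaves like a 2-fluorophenyl. In this assay compound 3 is therefore expected to show a 5.2-fold lower number from compound 2 to compound 3 (0.72 log units; beyond the scatter), a decrease toward the value of compound 1. The estimate for compound 3 is 11000 nM, with a range from 3500 nM to 40000 nM.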

Compound 3, half-maximal inhibitory concentration: 40500 nM
Beside the measured number, compound 3's estimate is 3.7-fold (0.57 log units) below it; the measured number lies above the stated range.
By their numbers in this assay, from the lowest: compound 1; then compounds 3 and 2 (each within the scatter of the next).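

In this assay, the step of a 1.4-fold lower number from compound 2 to compound 3 (0.15 log units; within the scatter) gives no separation between 4-fluorophenyl and 2,4-dichlorophenyl on this saturated chain carbon, so removing the chlorine atoms in favour of a single fluorine does not by itself bring the number back toward that of compound 1. The step of a 6.3-fold higher number from compound 1 to compound 3 (0.80 log units; beyond the scatter) shows that the two fluorophenyl groups are not interchangeable at this place, although they have the same atom count and differ only in where the fluorine stands. Among these three compounds, the 2-fluorophenyl group of compound 1 is therefore the one that stands apart, and the 4-fluorophenyl and 2,4-dichlorophenyl groups read alike in this assay.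

The compounds shown leave open whether the lower number of compound 1 depends on fluorine at all or on the 2-fluorophenyl pattern alone, and a plain phenyl group on the same chain carbon would set the baseline for that question. They also leave open how a ring carrying an amine or a carboxylic acid would read here. No measurement at hand explains the difference between the two fluorophenyl groups.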